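Compound 4 and an Inactive Neighbour

The source may hold more compounds than are shown below. What is called first, only, known or untested is meant among the compounds shown, and "the series" means these compounds.

- Compound 1 `Cc1ccc(C)c(N2CCN(C(=O)c3oc(C)nc3-c3ccccc3)CC2)c1`: 31.3 nM
- Compound 2 `C=C(C)c1ccc(N2CCN(C(=O)c3oc(C)nc3-c3ccccc3)CC2)cc1`: "not active" (no number reported)
- Compound 3 `Cc1cc(C)cc(N2CCN(C(=O)c3oc(C)nc3-c3ccccc3)CC2)c1`: 34.5 nM

In a functional assay on HL-60 cells (Homo sapiens) for inhibition, read by MTT assay, with a stated time of 72 h (a lower number here means a stronger inhibitor, a higher number a weaker inhibitor), compound 2 stands without a number, being reported as "not active" (no number reported). Compound 4 `Cc1nc(-c2ccccc2)c(C(=O)N2CCN(c3ccc(C(=O)C(C)C)cc3)CC2)o1` differs from it in one place: isopropylcarbonyl in place of 1-methylethenyl on an aromatic carbon. Isopropylcarbonyl takes the place of 1-methylethenyl on an aromatic carbon, para to a large group.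

Among the measured compounds shown here, the only measured step, a 1.1-fold higher number from compound 1 to compound 3 (0.04 log units; within the scatter), exchanges 2,5-dimethylphenyl for 3,5-dimethylphenyl. It does not involve either group in the new change, so it offers no size for this one. For the measured compounds named here, no step from compound 2 can be calculated either.

Compound 4 keeps a substituent at the place where compound 2 reads "not active" (no number reported). A value weaker than those of the two dimethylphenyl compounds is therefore expected in this assay, and a result without a number remains possible. The expected value for compound 4 is 200 nM, with an estimated range of 25 nM to 2500 nM.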

Compound 4, half-maximal inhibitory concentration: "not active" (no number reported)
Compound 4: no number reported; there is nothing to compare the estimate with.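

In this assay, among the compounds shown here, compound 2 and compound 4 both stand without a number, so no step between them can be read. The compounds shown leave open whether any group para to a large group on that aromatic carbon gives a numbered value. Nothing shown offers an explanation for either result.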